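Swapping a Piperazinylpropoxy Chain for an Isoxazolylmethoxy Group

The compounds below may be only part of what the source reports. "The series", "measured", "known", "first", "only" and "open" are said of these compounds alone.

Among the measured compounds shown here, compound 1 `COc1c(OCCCN2CCNCC2)cc(O)c2c(=O)cc(-c3ccccc3)oc12` is the only member of this small set with a numerical result: in a functional assay on A549 cells (Homo sapiens) for cytotoxicity, read by MTT assay, with a stated time of 48 h (a higher number here means a weaker inhibitor, a lower number a stronger inhibitor), compound 1 gives 10100 nM. Compound 2 `CN1CCN(CCCOc2c(O)cc(O)c3c(=O)cc(-c4ccccc4)oc23)CC1` reaches only the limit of this assay, and for compound 2 the result is > 100000 nM. Compound 3 `CNCCOc1c(O)cc(O)c2c(=O)cc(-c3ccccc3)oc12` has no reported result; for compound 3 the entry in this assay reads "not determined" (no result reported). One further observation applies to the set as a whole: the limit of > 100000 nM in this assay, at which 1 of the 3 values shown sits.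

Compound 4 `COc1c(OCc2cnoc2C)cc(O)c2c(=O)cc(-c3ccccc3)oc12` differs from compound 1 in a single place: 5-methyl-1,2-oxazol-4-yl in place of 2-(piperazin-1-yl)ethyl on a saturated chain carbon bound to an oxygen on an aromatic ring. For the measured compounds named here, no measured step connects compound 1 and compound 4, so there is nothing directly comparable to lean on. Given that compound 1 already sits at 10100 nM, compound 4 is expected to stay in the same weak region, with a step of a 1.5-fold higher number from compound 1 to compound 4 (0.17 log units; within the scatter) that is expected to be small and probably not beyond the scatter, if anything toward weaker inhibition. Compound 4 is therefore estimated at 15000 nM, within a range from 4000 nM to 60000 nM.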

Compound 4, half-maximal inhibitory concentration: > 100000 nM
Compound 4 gave a limit, no number; the forecaster's own chance of this, stated with the estimate: 25%; at least 6.6-fold (0.82 log units) between middle value and limit.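

In this assay, compound 4 reads > 100000 nM, which is a limit of the assay and not a number. Among the compounds shown here, exchanging the 3-(piperazin-1-yl)propoxy group for (5-methyl-1,2-oxazol-4-yl)methoxy on the shared core comes with an at least 9.9-fold higher number from compound 1 to compound 4 (0.99 log units; beyond the scatter), the first single-place comparison in this set, and it shows that this position does not tolerate every change. Compound 1 remains the only compound here with a number rather than a limit or an empty entry: the limit of > 100000 nM in this assay, at which 2 of the 4 values shown sit.

Going by these compounds, what stays open is whether the step belongs to the loss of the piperazine ring or to the shorter link, as the two change together here. How a morpholine ring on the same propoxy chain would read remains an open question.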